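Swapping methoxy for trifluoromethyl on the outer ring

This account rests on a few compounds, and the source may have more. Where it says the series, first, only, none or still open, it means among the compounds named here.

Measured compounds:
Compound 1, `O=C(Nc1cccc(-c2cccc(F)c2)c1)C(Cl)Cl`: 9530 nM
Compound 2, `COc1cccc(-c2cccc(NC(=O)C(Cl)Cl)c2)c1`: 4310 nM

Both were tested in a functional assay on A549 cells (Homo sapiens) for cytotoxicity, read by MTT assay, with a stated time of 68 h; a higher number here means a weaker inhibitor, a lower number a stronger inhibitor. Within the data shown here, compound 2 gives the lowest of the two numbers; its nearest neighbour is compound 1, and the only measured step, a 2.2-fold lower number from compound 1 to compound 2 (0.34 log units; beyond the scatter), is modest but beyond the scatter. Compound 3, `O=C(Nc1cccc(-c2cccc(C(F)(F)F)c2)c1)C(Cl)Cl`, is not yet measured. Its change from compound 2 is trifluoromethyl in place of methoxy on an aromatic carbon. Among the measured compounds shown here, no measured step shows trifluoromethyl against methoxy, so the fluoro-to-methoxy step is the only guide, and it points to methoxy giving a lower number than a small fluorine-bearing group at this position. Compound 3 is therefore expected to give a somewhat higher number than compound 2, a step of a 1.6-fold higher number from compound 2 to compound 3 (0.21 log units; within the scatter), with wide uncertainty. The estimate for compound 3 in this assay is 7000 nM, within a range of 3000 nM to 17000 nM.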

Compound 3, half-maximal inhibitory concentration: 18500 nM
For compound 3 the middle estimate is 2.6-fold (0.42 log units) below the measured one; measured number above the stated range.
By their numbers in this assay, from the lowest: compound 2; then compounds 1 and 3 (each within the scatter of the next).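

The outer-ring position in this assay now carries a third group, and trifluoromethyl in place of methoxy gives a clear rise (a 4.3-fold higher number from compound 2 to compound 3 (0.63 log units; beyond the scatter)), so methoxy's advantage is no longer seen against fluoro alone. Trifluoromethyl and fluoro, by contrast, cannot be told apart here (a 1.9-fold higher number from compound 1 to compound 3 (0.29 log units; within the scatter)), leaving methoxy as the one group of the three that stands apart. Nothing available here explains why methoxy separates from the other two.

The compounds shown leave open whether the lower number of compound 2 depends on the oxygen of methoxy, which a hydroxyl, an ethoxy or an amine at the same place could help to test. They also leave open whether methoxy would stand apart in the same way elsewhere on the outer ring.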